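Swapping the aminoethyl amide for a methylpiperidine amide

The source may report more compounds than this note shows. Statements on the series, on what has been measured and on what is new or still open speak of the compounds shown alone.

Of the compounds shown here, three sharing one core have been measured in an assay on HEK293 cells for displacement of a labelled ligand from NPC1-like intracellular cholesterol transporter 1 (Homo sapiens); on this read-out lower numbers stand for stronger inhibition and higher numbers for weaker inhibition. Compound 1 `CC(C)(C)OC(=O)NCC1CCCN(C(=O)CN2CN(c3ccccc3)C3(CCN(C(=O)c4ccc(C5CCCCC5)cc4)CC3)C2=O)C1` gives 3800 nM. Compound 2 `CS(=O)(=O)NCCNC(=O)CN1CN(c2ccccc2)C2(CCN(C(=O)c3ccc(C4CCCCC4)cc3)CC2)C1=O` gives 2100 nM, and compound 3 `NCCNC(=O)CN1CN(c2ccccc2)C2(CCN(C(=O)c3ccc(C4CCCCC4)cc3)CC2)C1=O` gives 3800 nM. Among the measured compounds shown here, the single one-point step among them, a 1.8-fold higher number from compound 2 to compound 3 (0.26 log units; within the scatter), shows that the change on that amine nitrogen left the read-out essentially where it was. Compound 3 thus stands level with compound 1 at the digits shown, the two together holding the highest numbers of the three, while compound 2 lies within the scatter of both.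

Compound 4 `CC1CCCN(C(=O)CN2CN(c3ccccc3)C3(CCN(C(=O)c4ccc(C5CCCCC5)cc4)CC3)C2=O)C1` arises from compound 3 by the change (3-methylpiperidin-1-yl in place of (2-aminoethyl)amino on a carbonyl carbon). For the measured compounds named here, no measured step touches this exact exchange; the only step on record, from compound 2 to compound 3, concerns a different position and was itself within the scatter. Since compound 1, compound 2 and compound 3 all sit within the scatter of one another despite their differing substituents at this end of the molecule, compound 4 is expected to show no step beyond the scatter, with a 1.1-fold lower number from compound 3 to compound 4 (0.04 log units; within the scatter). Compound 4 is therefore estimated at 3500 nM in this assay , with a range from 1200 nM to 10000 nM.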

Compound 4, half-maximal inhibitory concentration: 3600 nM
Compound 4: the middle estimate sits 1.0-fold (0.01 log units) below what was measured, within the range that was stated.
By their numbers in this assay, from the lowest: compounds 2, 4, 1 and 3 (each within the scatter of the next).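

In this assay, replacing (2-aminoethyl)amino on the carbonyl carbon with 3-methylpiperidin-1-yl gives a 1.1-fold lower number from compound 3 to compound 4 (0.02 log units; within the scatter), so an open chain with 2 hydrogen-bond donors gives way to a six-membered non-aromatic ring with 0 hydrogen-bond donors and the read-out stays within the scatter. The same ring in place of (2-(methanesulfonamido)ethyl)amino gives a 1.7-fold higher number from compound 2 to compound 4 (0.23 log units; within the scatter), and hydrogen in place of (tert-butoxycarbonyl)amino on the saturated chain carbon gives a 1.1-fold lower number from compound 1 to compound 4 (0.02 log units; within the scatter), which shows that the simple methyl-bearing ring of compound 4 is enough to stay within the scatter of all three earlier compounds, without any of their extended substituents. No measurement is at hand that would explain this insensitivity.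

The compounds shown leave open whether a carboxylic acid, a longer alkyl chain or a piperidine without the methyl at this carbonyl carbon would give a step beyond the scatter. With every step here within the scatter, they also leave open whether any change at this end of the molecule moves the read-out at all.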